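Dimethoxybenzyl ether series: removing one methoxy

The compounds below may be only part of what the source reports. "The series", "measured", "known", "first", "only" and "open" are said of these compounds alone.

Compound 2 `COc1cc(COc2ccc(OC)cc2CCCNC(C)=O)cc(OC)c1` stands lowest of the two numbers obtained in an assay on CHO cells for displacement of a labelled ligand from melatonin receptor type 1B (Homo sapiens), read by scintillation counting, with a stated time of 60 min (on this read-out higher numbers stand for weaker inhibition and lower numbers for stronger inhibition), where compound 2 gives 0.0326 nM. Compound 1 `COc1ccc(OCCCc2ccccc2)c(CCCNC(C)=O)c1` is the only comparator; in this assay compound 1 gives 72.2 nM, and the two values lie far apart, beyond the scatter. Compound 3 `COc1cccc(COc2ccc(OC)cc2CCCNC(C)=O)c1` is not yet measured. It differs from compound 2 by hydrogen in place of methoxy on an aromatic carbon. Within the data shown here, no step between measured compounds bears on this change; a modest weakening is expected, close to the scatter, so the estimated step of a 3.1-fold higher number from compound 2 to compound 3 (0.49 log units; beyond the scatter) is small. Compound 3 is expected to give about 0.1 nM, between 0.02 nM and 0.6 nM.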

Compound 3, inhibition constant: 0.00069 nM
Compound 3: middle estimate off by 140-fold (2.16 log units), on the high side; measured number outside the range, below it.
By their numbers in this assay, from the lowest: compound 3; then compound 2; then compound 1.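

In this assay the loss of one methoxy gives a 47-fold lower number from compound 2 to compound 3 (1.67 log units; beyond the scatter) and shows that, on this ring, the second methoxy is not needed for a low number; in this pair, hydrogen on that aromatic carbon gives the lower one. Among these compounds, the 3-methoxyphenyl group in place of phenethyl gives a 100000-fold lower number from compound 1 to compound 3 (5.02 log units; beyond the scatter) as the largest step so far. No measurement at hand gives a cause for either step. Still open, on these data alone, is how a hydroxyl or a chlorine on that aromatic carbon would compare with hydrogen. As far as these compounds go, the effect of removing the remaining methoxy is also open.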